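A Methyl Group on the Shared Core and Solubility

The source may hold more compounds than are shown below. What is called first, only, known or untested is meant among the compounds shown, and "the series" means these compounds.

Compound 1 (`CC(C)Nc1nc(NCc2ccco2)c2ccccc2n1`) was tested in a physicochemical assay for solubility, at pH 2; on this read-out lower numbers stand for lower solubility and higher numbers for higher solubility. Compound 1 gives >= 30000 nM, which is a limit of the assay and not a number. Two measured changes start from compound 1. Compound 2 (`CC(C)Nc1nc(NCc2ccco2)c2cccc(Cl)c2n1`) carries chloro in place of hydrogen on an aromatic carbon. In this assay compound 2 gives >= 30000 nM, again a limit. Compound 3 (`Cc1ccc2nc(NC(C)C)nc(NCc3ccco3)c2c1`) carries methyl in place of hydrogen on an aromatic carbon. In this assay compound 3 gives >= 30000 nM, also a limit. Neither step can be sized, neither a step that the two limits leave unreadable from compound 1 to compound 2 nor a step that the two limits leave unreadable from compound 1 to compound 3, because of the limit of >= 30000 nM in this assay, at which 3 of the 3 values shown sit.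

Compound 4 (`Cc1cccc2nc(NC(C)C)nc(NCc3ccco3)c12`) differs from compound 1 by methyl in place of hydrogen on an aromatic carbon. The two measured steps bear on this change, since both add a small group to an aromatic carbon of the shared core, but their sizes are not readable. The step that the limit leaves unreadable from compound 1 to compound 4 is therefore expected to stay within the scatter. Compound 4 is estimated at 40000 nM, within a range from 20000 nM to 100000 nM, and most likely it will again be reported only as a limit.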

Compound 4, solubility: >= 30000 nM
Compound 4 was reported as a limit; the forecaster's own chance of this, stated with the estimate: 85%; the middle value lies beyond the limit too.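

The step from compound 1 to compound 4 cannot be sized, because both compounds stop at the same limit: the limit of >= 30000 nM in this assay, at which 4 of the 4 values shown sit. As far as these compounds go, whether the chloro in compound 2 or the methyl in compound 3 and compound 4 changes solubility at all remains open.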